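The source may hold more compounds than are shown below. What is called first, only, known or untested is meant among the compounds shown, and "the series" means these compounds.

Compound 1 `NC1=NC2(CCSCC2)N(OCCCOc2cccc(Cl)c2)C(N)=N1` was tested in a functional assay on MDA-MB-231 cells (Homo sapiens) for antiproliferative activity, read by MTT assay, with a stated time of 72 h; a lower number here means a stronger inhibitor, a higher number a weaker inhibitor. In this assay compound 1 gives 130 nM. Going by the values given here, compound 3 `NC1=NC2(CCOCC2)N(OCCCOc2ccccc2Cl)C(N)=N1` gives 1430 nM in this assay, so compound 1 holds the lowest of the two numbers known, and the gap to compound 3 lies beyond the usual scatter. For compound 2 `NC1=NC2(CCOCC2)N(OCCCOc2cc(Cl)c(Cl)cc2Cl)C(N)=N1` no result was reported in this assay, where compound 2 stands as "not determined" (no result reported). Compound 4 `NC1=NC2(CCSCC2)N(OCCCOc2ccc(Cl)cc2)C(N)=N1` differs from compound 1 only in its chlorophenyl group: 4-chlorophenyl in place of 3-chlorophenyl on an oxygen on a saturated carbon. Among the compounds with values here, no measured pair shows this change, so no step can be borrowed from it. A step of modest size is expected in this assay, in either direction, most likely not far beyond the scatter. Compound 4 is expected to give 250 nM, within 60 nM to 1000 nM. This estimate corresponds to an expected step of a 1.9-fold higher number from compound 1 to compound 4 (0.28 log units; within the scatter).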

Compound 4, half-maximal inhibitory concentration: 350 nM
The estimate for compound 4 lay 1.4-fold (0.15 log units) below the measured number; the measured number falls inside the stated range.
By their numbers in this assay, from the lowest: compound 1; then compound 4; then compound 3.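

In this assay the change gives a 2.7-fold higher number from compound 1 to compound 4 (0.43 log units; beyond the scatter) although the two compounds hold the same atoms, joined differently. Where the chlorine sits on the phenyl ring therefore matters at this position, though the step is modest. No measurement shown here explains this step. Going by these compounds, whether the same change gives a similar step on a different core remains open. So does how a plain phenyl or a 3-methoxyphenyl group would compare on an oxygen on a saturated carbon.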